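Swapping the pyridine substituent on the shared core

The source may hold more compounds than are shown below. What is called first, only, known or untested is meant among the compounds shown, and "the series" means these compounds.

Measured compounds:
- compound 1, `O=C(O)c1cc(-c2cnc(C(=O)CCc3ccc(-c4ccccc4)cc3)o2)ccn1`, 50 nM in an assay for inhibition of Fatty-acid amide hydrolase 1 (Rattus norvegicus); on this read-out lower numbers stand for stronger inhibition and higher numbers for weaker inhibition
- compound 2, `NC(=O)c1ccc(-c2cnc(C(=O)CCc3ccc(-c4ccccc4)cc3)o2)nc1`, 1.3 nM

Within the data shown here, compound 2 shows the lower of the two numbers measured so far; its nearest neighbour is compound 1, and the step of a 38-fold lower number from compound 1 to compound 2 (1.59 log units; beyond the scatter) lies well beyond the usual scatter. Compound 3, `COC(=O)c1ccc(-c2cnc(C(=O)CCc3ccc(-c4ccccc4)cc3)o2)cn1`, has not yet been measured. The change from compound 2 to compound 3 is 6-(methoxycarbonyl)pyridin-3-yl in place of 5-carbamoylpyridin-2-yl on an aromatic carbon. Among the measured compounds shown here, the only measured step, from compound 1 to compound 2, concerns a different exchange on the same position and therefore gives only loose guidance: it shows that the group at this place can move the number a great deal. With the hydrogen-bond donor of compound 2 gone, a modest move back toward a higher number is expected, namely a 3.8-fold higher number from compound 2 to compound 3 (0.59 log units; beyond the scatter). Compound 3 is therefore estimated at 5 nM, within a range of 1.5 nM to 20 nM.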

Compound 3, inhibition constant: 0.6 nM
Compound 3: middle estimate off by 8.3-fold (0.92 log units), on the high side; measured number outside the range, below it.
By their numbers in this assay, from the lowest: compound 3; then compound 2; then compound 1.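

In this assay the exchange of 5-carbamoylpyridin-2-yl for 6-(methoxycarbonyl)pyridin-3-yl gives a 2.2-fold lower number from compound 2 to compound 3 (0.34 log units; beyond the scatter) and so shows that a low number at this place does not depend on the hydrogen-bond donor of compound 2. Set against the 2-carboxypyridin-4-yl group of compound 1, the new group gives an 83-fold lower number from compound 1 to compound 3 (1.92 log units; beyond the scatter) and this means that both the carbamoyl and the methoxycarbonyl pyridines reach far lower numbers than the carboxylic acid in this small set. No measurement here explains these differences.

The functional group and the point at which the pyridine ring attaches change together in these steps, leaving the contribution of each one unresolved. A nitrile or an ethyl ester in place of the methoxycarbonyl group would test how much the number depends on the methyl ester itself.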